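The source may report more compounds than this note shows. Statements on the series, on what has been measured and on what is new or still open speak of the compounds shown alone.

Measured in an ADME assay on RAW264.7 cells (Mus musculus) for cytotoxicity, read by MTT assay; a lower number here means a stronger inhibitor, a higher number a weaker inhibitor:
- compound 1 `CCCCCCCCCCCCCCCCOc1cccc(O)c1C(=O)/C=C/c1ccc(O)cc1`: > 30000 nM (a limit)
- compound 2 `CCCCCCCCCCOc1cccc(O)c1C(=O)/C=C/c1ccc(O)c(Cl)c1`: > 30000 nM (a limit)

Compound 2 stands at > 30000 nM, which is a limit of the assay and not a number. Neither measured compound gives more than that, as the limit of > 30000 nM in this assay, at which 2 of the 2 values shown sit, shows. Compound 3 `CCCCCCCCCCOc1cccc(O)c1C(=O)/C=C/c1ccc(C)cc1` carries 4-methylphenyl in place of 3-chloro-4-hydroxyphenyl on a double-bonded chain carbon bound to a double-bonded chain carbon. Among the measured compounds shown here, no measured step is available, so no change beyond the scatter is expected in this assay, in either direction. The estimated change is a number no higher from compound 2 to compound 3 (the limit leaves the size open). The estimate for compound 3 is 30000 nM, with an expected range from 12000 nM to 60000 nM.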

Compound 3, half-maximal inhibitory concentration: > 30000 nM
Compound 3 was reported as a limit (the forecaster's own chance of this, stated with the estimate: 70%); the middle value sits exactly at the limit.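

No step can be read from compound 2 to compound 3 in this assay, as both results are limits of the assay and not numbers: the limit of > 30000 nM in this assay, at which 3 of the 3 values shown sit.

The compounds shown leave open what 4-methylphenyl in place of 3-chloro-4-hydroxyphenyl does to the read-out, and whether any compound of this kind gives a number in this assay.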